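A few compounds are considered here, and "the series" means these few. Any claim that something is new, unique, unknown or untested is made for them only; others in the source may bear on it.

Working notes on the series. Compound 1 `CCCCc1nc(=O)c(S(=O)(=O)c2ccc(-c3ccc(F)cc3)cc2)c(O)n1-c1c(OC)cccc1OC` in an ADME assay on microsomes from liver (Homo sapiens) for metabolic stability, using NADPH, with a stated time of 10 min (a lower number here means that less of the compound is left, a higher number that more of the compound is left), gives 100%. Compound 2 `CCCCc1[nH]c(=O)c(S(=O)(=O)c2ccc(-n3ccccc3=O)cc2)c(O)c1-c1c(OC)cccc1OC` in this assay gives 100%. Compound 1 is thus level with compound 2 at the digits shown, the two values lying within the scatter of each other, and no other measured compound stands near it. Compound 3 `CCCCc1nc(=O)c(S(=O)(=O)c2ccc(C)cc2)c(O)n1-c1c(OC)cccc1OC` has not yet been measured in this assay. It differs from compound 1 by methyl in place of 4-fluorophenyl on an aromatic carbon, para to a large group. For the measured compounds named here, no pair of measured compounds differing in one place is available, so the size of such a change cannot be read from the measured data. Both measured compounds sit at the top of the read-out in this assay, which leaves room only for a drop or for no change. The expectation is a small step downward or none beyond the scatter, and the estimated step of a number 10 percentage points lower from compound 1 to compound 3 (within the scatter) reflects that. Compound 3 is expected to give 90% in this assay, within an estimated range from 70% to 100%.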

Compound 3, percent of the compound remaining: 94%
Compound 3: the middle estimate sits 4 percentage points below what was measured; measured number inside the range.
By their numbers in this assay, from the lowest: compounds 3, 1 and 2 (each within the scatter of the next).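

In this assay, the exchange of 4-fluorophenyl for methyl on an aromatic carbon, para to a large group, can now be read directly as a number 6 percentage points lower from compound 1 to compound 3 (within the scatter). At this place, therefore, the seven heavy atoms and the six-membered aromatic ring of 4-fluorophenyl can give way to the single carbon of methyl with no step beyond the scatter, so this read-out does not separate the two groups, although this rests on one pair alone. Nothing available explains this outcome or ties it to any feature of either group.

Still open, going by these compounds, is whether an amine, a carboxylic acid or a longer chain such as n-propyl at this same place would give a step beyond the scatter, or would stay as close to compound 1 as methyl does. Also open, on these data alone, is whether the exchange of 4-fluorophenyl for methyl would give a similar step on a core other than that of compound 1, since a single pair cannot show how far this result carries.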